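The source may report more compounds than this note shows. Statements on the series, on what has been measured and on what is new or still open speak of the compounds shown alone.

Working notes on the benzyloxy series sharing the core of compound 1 `Cc1ccc(NC(=O)NC(=O)c2ccc(OCc3cccc(Cl)c3Cl)cc2)cc1-c1nc2ccccc2[nH]1`. In a functional assay on MNK45 cells (Homo sapiens) for inhibition, read by MTT assay, with a stated time of 48 h (on this read-out higher numbers stand for weaker inhibition and lower numbers for stronger inhibition), compound 1 gives 87000 nM. Compound 2 `Cc1ccc(NC(=O)NC(=O)c2ccc(OCc3cccc(F)c3)cc2)cc1-c1nc2ccccc2[nH]1`, carrying 3-fluorophenyl in place of 2,3-dichlorophenyl, gives 53000 nM in this assay, a change read as a 1.6-fold lower number from compound 1 to compound 2 (0.22 log units; within the scatter). Compound 3 `Cc1ccc(NC(=O)NC(=O)c2ccc(OCc3ccc(Cl)c(Cl)c3)cc2)cc1-c1nc2ccccc2[nH]1` gives 5820 nM and holds the lowest number of the three; the steps to it are a 15-fold lower number from compound 1 to compound 3 (1.17 log units; beyond the scatter) and a 9.1-fold lower number from compound 2 to compound 3 (0.96 log units; beyond the scatter), both beyond the scatter.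

Compound 4 `Cc1ccc(NC(=O)NC(=O)c2ccc(OCc3ccc(Cl)cc3Cl)cc2)cc1-c1nc2ccccc2[nH]1` is the unmeasured member; the change from compound 3 is 2,4-dichlorophenyl in place of 3,4-dichlorophenyl on a saturated chain carbon bound to an oxygen on an aromatic ring. The steps bearing on it are those into compound 3: the move from 2,3-dichlorophenyl produced a 15-fold lower number from compound 1 to compound 3 (1.17 log units; beyond the scatter), the move from 3-fluorophenyl a 9.1-fold lower number from compound 2 to compound 3 (0.96 log units; beyond the scatter). Since the chlorine arrangement of compound 4 differs from compound 3 as compound 1 did, a return toward the higher numbers is expected, though shared chlorine placement with compound 3 argues for only part of that step. The expected step from compound 3 to compound 4 is a 4.3-fold higher number from compound 3 to compound 4 (0.63 log units; beyond the scatter), toward weaker inhibition. Compound 4 is therefore estimated at 25000 nM in this assay, within a range of 6000 nM to 90000 nM.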

Compound 4, half-maximal inhibitory concentration: 2550 nM
Compound 4: the middle estimate sits 9.8-fold (0.99 log units) above what was measured, and the stated range ends above it.
By their numbers in this assay, from the lowest: compound 4; then compound 3; then compounds 2 and 1 (each within the scatter of the next).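

Among three groups of identical atom count, the arrangement of the two chlorines decides the outcome in this assay: a 2.3-fold lower number from compound 3 to compound 4 (0.36 log units; beyond the scatter), and a 34-fold lower number from compound 1 to compound 4 (1.53 log units; beyond the scatter), so the 3,4-dichlorophenyl of compound 3 is not the best arrangement among those shown. Compound 4 now holds the lowest number of the series, with a 21-fold lower number from compound 2 to compound 4 (1.32 log units; beyond the scatter), and its steps to all three others lie beyond the scatter. Nothing shown gives a measured reason why these isomers separate.

Going by these compounds, whether the order of the chlorine arrangements carries over to other groups on the same saturated chain carbon remains open, for example a carboxylic acid or an amine on the ring. Also open, on these data alone, is how a longer chain between the oxygen and the 2,4-dichlorophenyl ring would read in this assay.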